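Swapping an aryl for a thiazole on the piperazine nitrogen

The compounds below may be only part of what the source reports. "The series", "measured", "known", "first", "only" and "open" are said of these compounds alone.

Measured so far:
compound 1, `O=C(CN1CCN(c2cccc(F)c2)CC1)Nc1nc2c(s1)CCCC2`: > 1000 nM
compound 2, `O=C(CN1CCN(c2ccc(F)cc2)CC1)Nc1nc2c(s1)CCC2`: 490 nM

In an assay on isolated protein for inhibition of long-chain fatty acid transport protein 1 (Homo sapiens), read by scintillation counting, with a stated time of 20 min (on this read-out lower numbers stand for stronger inhibition and higher numbers for weaker inhibition), compound 1 gives > 1000 nM, which is a limit of the assay rather than a number. Compound 1 thus stands at the limit of > 1000 nM in this assay, at which 1 of the 2 values shown sits. Compound 2, `O=C(CN1CCN(c2ccc(F)cc2)CC1)Nc1nc2c(s1)CCC2`, gives 490 nM in this assay. Compound 3, `O=C(CN1CCN(c2nccs2)CC1)Nc1nc2c(s1)CCCC2`, differs from compound 1 by 1,3-thiazol-2-yl in place of 3-fluorophenyl on an amine nitrogen in a ring. Within the data shown here, no measured step of this kind exists, so the expected step that the limit leaves unreadable from compound 1 to compound 3 is small and within the scatter. Compound 3 is expected at 1500 nM, with a range from 500 nM to 5000 nM.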

Compound 3, half-maximal inhibitory concentration: 520 nM
The estimate for compound 3 lay 2.9-fold (0.46 log units) above the measured number, and the stated range covers the measured number.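

Among these compounds, compound 3 gives the first actual number for a compound with this core, showing that 1,3-thiazol-2-yl can replace 3-fluorophenyl on this ring nitrogen with no weakening in this assay. The change is an at least 1.9-fold lower number from compound 1 to compound 3 (0.28 log units; that floor lies within the scatter), so a real gain is not established. For compound 1 the read-out is a limit of the assay, not a number: the limit of > 1000 nM in this assay, at which 1 of the 3 values shown sits.

From the compounds shown here alone, the true size of the step remains unknown. Going by these compounds, it is also open how a pyridin-2-yl ring or a simple methyl group would fare on this nitrogen.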